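Trimethoxyphenyl-benzimidazole series: weighing a nitro variant

A few compounds are considered here, and "the series" means these few. Any claim that something is new, unique, unknown or untested is made for them only; others in the source may bear on it.

Compound 1 `COc1cc(-n2cnc3ccc(-c4cccc(N)c4)cc32)cc(OC)c1OC` gives 21 nM in a functional assay on SGC-7901 cells (Homo sapiens) for antiproliferative activity, read by MTT assay, with a stated time of 72 h; on this read-out higher numbers stand for weaker inhibition and lower numbers for stronger inhibition. Compound 2 `COc1cc(-n2cnc3ccc(-c4cccc(F)c4)cc32)cc(OC)c1OC` gives 2490 nM, and compound 3 `COc1cc(-n2cnc3ccc(-c4cccc(C)c4C)cc32)cc(OC)c1OC` gives 3040 nM. Between them, a 120-fold higher number from compound 1 to compound 2 (2.07 log units; beyond the scatter) and a 140-fold higher number from compound 1 to compound 3 (2.16 log units; beyond the scatter), whereas a 1.2-fold higher number from compound 2 to compound 3 (0.09 log units; within the scatter). Compound 3 therefore sits at the high end of the three values, indistinguishable within the scatter from compound 2 and far above compound 1. Compound 4 `COc1cc(-n2cnc3ccc(-c4cccc([N+](=O)[O-])c4)cc32)cc(OC)c1OC` differs from compound 3 by 3-nitrophenyl in place of 2,3-dimethylphenyl on an aromatic carbon. Among the compounds with values here, the steps that bear on this are the two large ones away from compound 1, both tied to loss of the 3-aminophenyl; compound 4 carries no amino group, so the step of a 1.2-fold lower number from compound 3 to compound 4 (0.08 log units; within the scatter) is expected to remain within the scatter. Compound 4 is estimated at 2500 nM, with a range from 800 nM to 8000 nM.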

Compound 4, half-maximal inhibitory concentration: 380 nM
Estimate against measurement, compound 4: 6.6-fold (0.82 log units) above, outside the stated range (below it).
By their numbers in this assay, from the lowest: compound 1; then compound 4; then compounds 2 and 3 (each within the scatter of the next).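

Loss of the amino group does not by itself fix the value at this position, and the groups without an amino group are not equivalent. Nitro in place of amino still costs much (an 18-fold higher number from compound 1 to compound 4 (1.26 log units; beyond the scatter)), but it retains more than the earlier replacements, as nitro in place of fluoro (a 6.6-fold lower number from compound 2 to compound 4 (0.82 log units; beyond the scatter)) and 3-nitrophenyl in place of 2,3-dimethylphenyl (an 8.0-fold lower number from compound 3 to compound 4 (0.90 log units; beyond the scatter)) both show. Open, on these data alone, is whether a hydroxyl or a carboxylic acid at this place would come closer to compound 1 than nitro does. Nothing at hand accounts for these gaps.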